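Hydroxy for Nitrile on a Scaffold at the Assay Limit

This account rests on a few compounds, and the source may have more. Where it says the series, first, only, none or still open, it means among the compounds named here.

Compound 1 `COC(=O)CC/C(C)=C/Cc1c(OC)c(C)c2c(c1OCC#CCN1CCN(c3ccc(C#N)cc3)CC1)C(=O)OC2` was tested in a functional assay on FaDu cells (Homo sapiens) for inhibition, read by sulforhodamine B assay; a lower number here means a stronger inhibitor, a higher number a weaker inhibitor. In this assay compound 1 gives only a limit, > 50000 nM, not a measured number. Compound 2 `COC(=O)CC/C(C)=C/Cc1c(OC)c(C)c2c(c1OCC#CCN1CCC(Cc3ccccc3)CC1)C(=O)OC2` likewise reaches only a limit, > 50000 nM. Compound 3 `CCCCNc1ccc(CC#CCOc2c(C/C=C(\C)CCC(=O)OC)c(OC)c(C)c3c2C(=O)OC3)cc1` gives 21200 nM in this assay. Compound 1 therefore stands at the weak end of the measured series, alongside compound 2, because of the limit of > 50000 nM in this assay, at which 2 of the 3 values shown sit. Compound 4 `COC(=O)CC/C(C)=C/Cc1c(OC)c(C)c2c(c1OCC#CCN1CCN(c3ccc(O)cc3)CC1)C(=O)OC2` differs from compound 1 by hydroxy in place of cyano on an aromatic carbon. Among the measured compounds shown here, no measured pair shows what this change does in this assay. The step of an at least 1.1-fold lower number from compound 1 to compound 4 (0.04 log units; that floor lies within the scatter) is expected to be small or none beyond the scatter. Compound 4 is expected most likely to give again only a limit and is estimated at 45000 nM, between 15000 nM and 150000 nM.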

Compound 4, half-maximal inhibitory concentration: > 50000 nM
Compound 4 was reported as a limit; the forecaster's own chance of this, stated with the estimate: 60%; middle value at least 1.1-fold (0.04 log units) from the limit.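

In this assay compound 1 and compound 4 each give only a limit, so no step can be read between them. The compounds shown leave open whether hydroxy in place of cyano changes inhibition at all.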